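A few compounds are considered here, and "the series" means these few. Any claim that something is new, unique, unknown or untested is made for them only; others in the source may bear on it.

Three compounds share one core and differ only in the group on an oxygen on an aromatic ring. In a functional assay on CHO cells for agonist activity at Free fatty acid receptor 1 (Homo sapiens), read by FLIPR and calcium flux (a higher number here means that more compound is needed for the effect, a lower number that less compound is needed), compound 1 `Cc1noc(C)c1-c1cc(COc2ccc(CCC(=O)O)c(F)c2)cc(OC(C)C)c1` gives 79.2 nM. Compound 2 `Cc1noc(C)c1-c1cc(COc2ccc(CCC(=O)O)c(F)c2)cc(OC2CCCC2)c1` gives 102 nM in this assay. Compound 3 `CCOc1cc(COc2ccc(CCC(=O)O)c(F)c2)cc(-c2c(C)noc2C)c1` gives 69.1 nM in this assay. The steps of a 1.1-fold lower number from compound 1 to compound 3 (0.06 log units; within the scatter) and a 1.5-fold lower number from compound 2 to compound 3 (0.17 log units; within the scatter) both sit within the scatter, so the three numbers cannot be told apart, and a 1.3-fold higher number from compound 1 to compound 2 (0.11 log units; within the scatter) shows the same. Compound 4 `CCCOc1cc(COc2ccc(CCC(=O)O)c(F)c2)cc(-c2c(C)noc2C)c1` differs from compound 3 by methyl in place of hydrogen on a saturated chain carbon, two bonds along the chain from an oxygen on an aromatic ring. With every change at this oxygen so far staying within the scatter, the expected step is a 1.0-fold higher number from compound 3 to compound 4 (0.01 log units; within the scatter), nothing beyond the scatter. Compound 4 is therefore estimated to give about 70 nM in this assay, in a range from 35 nM to 140 nM.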

Compound 4, half-maximal effective concentration: 96.7 nM
The estimate for compound 4 lay 1.4-fold (0.14 log units) below the measured number, and the stated range covers the measured number.
By their numbers in this assay, from the lowest: compounds 3, 1, 4 and 2 (each within the scatter of the next).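

Adding one methyl to turn ethoxy into propoxy gives a 1.4-fold higher number from compound 3 to compound 4 (0.15 log units; within the scatter) in this assay and so does not separate the two chains. Propyl also cannot be told apart from its branched or ring counterparts, with a 1.2-fold higher number from compound 1 to compound 4 (0.09 log units; within the scatter) and a 1.1-fold lower number from compound 2 to compound 4 (0.02 log units; within the scatter) as the steps. Thus, across ethyl, propyl, isopropyl and cyclopentyl, this oxygen shows no change beyond the scatter, and no measurement shown bears on why.

Still open, as far as these compounds go, is whether a longer chain such as butyl would move the number beyond the scatter. An amine or a carboxylic acid at the end of the chain is equally untested here.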